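This account rests on a few compounds, and the source may have more. Where it says the series, first, only, none or still open, it means among the compounds named here.

Measured so far:
- Compound 1, `O=C(Nc1ccc(F)cc1)Nc1cccc(CNc2ncnc3ccccc23)c1`: 41500 nM
- Compound 2, `COc1cc2ncnc(NCc3cccc(NC(=O)Nc4ccccc4)c3)c2cc1OC`: 19700 nM

Both compounds were tested in a functional assay on HepG2 cells (Homo sapiens) for antiproliferative activity, read by MTT assay; on this read-out lower numbers stand for stronger inhibition and higher numbers for weaker inhibition. Compound 2 stands at the lower of the two numbers, and its step to compound 1 lies beyond the scatter, so compound 2 is the stronger of the two here. The unmeasured compound 3, `COc1cc2ncnc(NCc3cccc(NC(=O)Nc4ccccc4C)c3)c2cc1OC`, is the next step from compound 2: methyl in place of hydrogen on an aromatic carbon. Among the compounds with values here, nothing measured so far shows what a change of this kind does in this assay, so the expectation rests on the small size of the added group alone. A step of no more than the usual scatter is expected from compound 2 to compound 3, in either direction. The estimate for compound 3 in this assay is 20000 nM, with a range from 7000 nM to 55000 nM, which means an expected step of a 1.0-fold higher number from compound 2 to compound 3 (0.01 log units; within the scatter).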

Compound 3, half-maximal inhibitory concentration: > 50000 nM
Compound 3 gave a limit, no number; the forecaster's own chance of this, stated with the estimate: 5%; middle value at least 2.5-fold (0.39 log units) away from the limit.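

In this assay, compound 3 gives a limit and not a number: the limit of > 50000 nM in this assay, at which 1 of the 3 values shown sits.

Even as a limit, it gives a readable result: a single methyl on an aromatic carbon of the phenyl ring, ortho to a large group, gives an at least 2.5-fold higher number from compound 2 to compound 3 (0.40 log units; beyond the scatter). Compound 1 and compound 2 differ in more than one place, so neither could show what one added carbon does at this position.

As far as these compounds go, how large the step really is stays open, as does whether it belongs to the methyl itself or to any group at this place. A chloro group or an amine on the same carbon, or a methyl on another carbon of that ring, would help to tell these apart.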